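The source may report more compounds than this note shows. Statements on the series, on what has been measured and on what is new or still open speak of the compounds shown alone.

The measured compounds are these. Compound 1 is `CC(C)(C)OC(=O)N1CCC[C@H]1C(=O)N1CCC(NS(=O)(=O)c2cc(S(=O)(=O)c3ccccc3)ccc2C(F)(F)F)CC1`. In a functional assay on U2OS cells for antagonist activity at proto-oncogene Wnt-3 (Homo sapiens), read by a luciferase reporter, with a stated time of 18 h (a lower number here means that less compound is needed, a higher number that more compound is needed for the effect), compound 1 gives 60 nM. Compound 2 is `CC(C)(C)CC(=O)N1CCC[C@H]1C(=O)N1CCC(NS(=O)(=O)c2cc(S(=O)(=O)c3ccccc3)ccc2C(F)(F)F)CC1`. In this assay compound 2 gives 120 nM.

Where compound 2 stands among these numbers is quickly told: the single step that connects the measured compounds, a 2.0-fold higher number from compound 1 to compound 2 (0.30 log units; within the scatter), leaves the two within the scatter of each other, so neither can be called the more potent. That step exchanged one group on the carbonyl carbon of the shared core for another without moving the number beyond what repeated measurement would give.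

Compound 3, `O=C([C@@H]1CCCN1C(=O)c1ccncc1)N1CCC(NS(=O)(=O)c2cc(S(=O)(=O)c3ccccc3)ccc2C(F)(F)F)CC1`, is the next compound on this path. It differs from compound 2 by pyridin-4-yl in place of neopentyl on a carbonyl carbon. Within the data shown here, the only measured step that bears on this position is a 2.0-fold higher number from compound 1 to compound 2 (0.30 log units; within the scatter), which was small, and it involved no aromatic group; for an aromatic ring with a ring nitrogen at this place there is no measured comparison. On that footing compound 3 is expected to stay near compound 2, with the step of a 1.3-fold higher number from compound 2 to compound 3 (0.10 log units; within the scatter) estimated to fall within the scatter, and a wide range kept open. The estimate for compound 3 in this assay is 150 nM, between 50 nM and 500 nM.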

Compound 3, half-maximal effective concentration: 350 nM
The estimate for compound 3 lay 2.3-fold (0.37 log units) below the measured number, within the range that was stated.
By their numbers in this assay, from the lowest: compounds 1 and 2 (each within the scatter of the next); then compound 3.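

With the third compound, this position on the carbonyl carbon, where the earlier pair had stayed within the scatter, gives a difference beyond it: in this assay pyridin-4-yl in place of neopentyl gives a 2.9-fold higher number from compound 2 to compound 3 (0.46 log units; beyond the scatter) and pyridin-4-yl in place of tert-butoxy gives a 5.8-fold higher number from compound 1 to compound 3 (0.77 log units; beyond the scatter) on the same shared core. Of the three groups seen at this place, only pyridin-4-yl, the one with an aromatic ring and a ring nitrogen, stands apart from the others, so the position is not indifferent to what it carries, and compound 3 needs the most compound for the effect of the three. Nothing measured here accounts for this difference.

The compounds shown leave open whether the higher number goes with the aromatic ring as such or with its ring nitrogen, a question that a phenyl group on this carbonyl carbon would address. Also open, as far as these compounds go, is how an amine, a carboxylic acid or a longer chain at this place would compare with neopentyl and tert-butoxy.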